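Chain length and piperidine variation in one series

The source may hold more compounds than are shown below. What is called first, only, known or untested is meant among the compounds shown, and "the series" means these compounds.

Measured compounds:
Compound 1 `COc1ccc(-c2cc(=O)c3ccc(OCCCCN4CCC(CCO)CC4)cc3o2)cc1`: in a functional assay, read by spectrophotometry (on this read-out higher numbers stand for an effect only at larger amounts of compound and lower numbers for an effect already at smaller amounts), compound 1 gives 23.2 nM.
Compound 2 `COc1ccc(-c2cc(=O)c3ccc(OCCCCCN4CCC(C)CC4)cc3o2)cc1`: in this assay compound 2 gives 31.7 nM.
Compound 3 `COc1ccc(-c2cc(=O)c3ccc(OCCCCCN4CCC(CCO)CC4)cc3o2)cc1`: in this assay compound 3 gives 27.9 nM.

The three values sit close together. Compound 1 and compound 3 share the same piperidine substituent and differ only in the chain, ((4-(2-hydroxyethyl)piperidin-1-yl)methyl in place of 4-(2-hydroxyethyl)piperidin-1-yl on a saturated chain carbon, four bonds along the chain from an oxygen on an aromatic ring), and the step of a 1.2-fold higher number from compound 1 to compound 3 (0.08 log units; within the scatter). Compound 2 and compound 3 share the longer chain and differ only at the ring, with a 1.1-fold lower number from compound 2 to compound 3 (0.06 log units; within the scatter).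

The change of interest is (4-methylpiperidin-1-yl)methyl in place of 4-(2-hydroxyethyl)piperidin-1-yl on a saturated chain carbon, four bonds along the chain from an oxygen on an aromatic ring, which in the measured pair gave a 1.4-fold higher number from compound 1 to compound 2 (0.14 log units; within the scatter). Compound 4 `COc1ccc(-c2cc(=O)c3ccc(OCCCCCCN4CCC(C)CC4)cc3o2)cc1`, not yet measured, arises from compound 3 by (4-methylpiperidin-1-yl)methyl in place of 4-(2-hydroxyethyl)piperidin-1-yl on a saturated chain carbon, five bonds along the chain from an oxygen on an aromatic ring. The two changes are the same kind of change but not the same: in the first the place is four bonds along the chain from an oxygen on an aromatic ring, in the second five bonds along the chain from the same oxygen. The chain around the place is therefore one carbon longer in compound 4 than in compound 2.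

Given that no change among these three compounds moved the number beyond the scatter, the step from compound 3 to compound 4 is expected to be of similar size, a 1.4-fold higher number from compound 3 to compound 4 (0.13 log units; within the scatter), resting on the step of a 1.4-fold higher number from compound 1 to compound 2 (0.14 log units; within the scatter) seen for the same kind of change. Compound 4 is accordingly estimated at 38 nM in this assay, with a likely range from 20 nM to 75 nM.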

Compound 4, half-maximal effective concentration: 32.6 nM
Beside the measured number, compound 4's estimate is 1.2-fold (0.07 log units) above it; low and high end bracket the measured number.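

In this assay, the change to (4-methylpiperidin-1-yl)methyl in place of 4-(2-hydroxyethyl)piperidin-1-yl gives steps on the two cores that cannot be told apart: the same change on two cores in this assay, a 1.4-fold higher number (0.14 log units; within the scatter) from compound 1 to compound 2 and a 1.2-fold higher number (0.07 log units; within the scatter) from compound 3 to compound 4, 1.2-fold (0.07 log units) apart, within the scatter of two such steps

The new step, a 1.2-fold higher number from compound 3 to compound 4 (0.07 log units; within the scatter), therefore agrees with the earlier one, and the other two new steps, a 1.0-fold higher number from compound 2 to compound 4 (0.01 log units; within the scatter) and a 1.4-fold higher number from compound 1 to compound 4 (0.15 log units; within the scatter), also stay within the scatter, so all four compounds remain indistinguishable on this read-out. This agreement does not show that the change transfers in any stronger sense: neither step is distinguishable from no effect, so the comparison cannot say whether a change that really moved the number would carry over in the same way, and two pairs in one assay give no general rule for other cores.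

The compounds shown leave open whether a shorter chain, or a carboxylic acid in place of the hydroxyl on the piperidine substituent, would move the number beyond the scatter. Also open, on these data alone, is whether 4-(2-hydroxyethyl)piperidin-1-yl on the chain of compound 4 would stay within the scatter of these values.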